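The compounds below may be only part of what the source reports. "The series", "measured", "known", "first", "only" and "open" are said of these compounds alone.

Working notes on the series. Two compounds of the shared core have numbers in a functional assay on the whole organism with Mus musculus as the target, read by paw edema, with a stated time of 360 min, at a dose of 50 mg/kg by the oral route; on this read-out higher numbers stand for a weaker effect at the one dose given and lower numbers for a stronger effect. Compound 1, `CCn1c(Cn2c(=O)oc3ccc(C)cc32)n[nH]c1=S`, gives 147% in this assay. Compound 2, `CCCNC(=S)NNC(=O)Cn1c(=O)oc2ccc(C)cc21`, gives 177% in this assay, the highest of the two numbers and, on this read-out, the weaker effect; the gap to compound 1 is beyond the scatter. Among the measured compounds shown here, no step between compounds that differ in one place is available, so no measured step size is known.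

Compound 3, `CNC(=S)NNC(=O)Cn1c(=O)oc2ccc(C)cc21`, has not been measured in this assay. It differs from compound 2 as follows: hydrogen in place of ethyl on a saturated chain carbon bound to an amide-type nitrogen. The same difference, cut one bond further out, reads propyl to methyl, propylamino to methylamino.

Nothing in the two numbers shows how a change on the saturated chain carbon bound to the amide-type nitrogen moves this read-out, so the step is expected to be small, with no direction beyond the scatter favoured; the expected step is a number 5 percentage points lower from compound 2 to compound 3 (within the scatter). Compound 3 is estimated at 172% in this assay, in a range from 140% to 205%.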

Compound 3, a percentage reported as activity, at one dose (the size of the read-out at that dose, not a potency): 189%
The estimate for compound 3 lay 17 percentage points below the measured number, within the range that was stated.
By their numbers in this assay, from the lowest: compound 1; then compound 2; then compound 3.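

This gives the series its first measured step at this position: in this assay, hydrogen in place of ethyl on a saturated chain carbon bound to an amide-type nitrogen, which reads as propylamino to methylamino, gives a number 12 percentage points higher from compound 2 to compound 3 (beyond the scatter) and so a weaker effect at the one dose given. The chain on this nitrogen is therefore not silent in this read-out, and the propyl chain of the pair goes with the stronger effect, although the step is modest and rests on a single pair of compounds. Nothing available on these compounds accounts for the direction or size of this step.

From the compounds shown here alone, with only propyl and methyl compared at this position, no trend along the chain can be claimed, and it remains open whether an ethyl chain would fall in line with them or a longer chain such as butyl would extend the direction. A branched chain such as isopropyl, a phenyl ring or a terminal carboxylic acid in the same place would show whether the step depends on chain length alone.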